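The compounds below may be only part of what the source reports. "The series", "measured", "known", "first", "only" and "open" are said of these compounds alone.

Working notes on the series, step from compound 1 to compound 4.

Compound 1, `COC(=O)C1=C(C)N=C(C)/C(=C(\O)OC)C1c1ccccc1I`, has been run in a functional assay (muscle tissue) with Cavia porcellus as the target (on this read-out lower numbers stand for an effect already at smaller amounts and higher numbers for an effect only at larger amounts of compound), where compound 1 gives 46.8 nM. Within the three measured compounds this is the lowest number; the nearest is compound 3, `COC(=O)C1=C(C)N=C(C)/C(=C(\O)OC)C1c1ccc(F)cc1`, which in this assay gives 129 nM, and the furthest is compound 2, `COC(=O)C1=C(C)N=C(C)/C(=C(\O)OC)C1c1cccc(N)c1`, which gives 2000 nM. The two steps away from compound 1 are both beyond the scatter: a 43-fold higher number from compound 1 to compound 2 (1.63 log units; beyond the scatter) and a 2.8-fold higher number from compound 1 to compound 3 (0.44 log units; beyond the scatter). Between the other two, a 16-fold lower number from compound 2 to compound 3 (1.19 log units; beyond the scatter).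

Compound 4, `COC(=O)C1=C(C)N=C(C)/C(=C(\O)OC)C1c1ccccc1C(F)(F)F`, keeps the shared core of compound 1 and differs only on the aromatic ring: trifluoromethyl in place of iodo on an aromatic carbon. Among the compounds with values here, none of the measured steps exchanges one group for another at the same place on the ring, so they bear on this change only indirectly. They show that the 3-aminophenyl of compound 2 costs a large step and the 4-fluorophenyl of compound 3 a modest one, while compound 1 with the 2-iodophenyl holds the lowest number. A group entering where iodo left is expected to keep compound 4 near compound 1, with a step of a 1.5-fold higher number from compound 1 to compound 4 (0.17 log units; within the scatter) expected, which may not exceed the scatter. In this assay compound 4 is therefore estimated at 70 nM, between 25 nM and 250 nM.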

Compound 4, half-maximal effective concentration: 1.51 nM
The estimate for compound 4 lay 46-fold (1.67 log units) above the measured number; the measured number lies below the stated range.
By their numbers in this assay, from the lowest: compound 4; then compound 1; then compound 3; then compound 2.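

In this assay the exchange of iodo for trifluoromethyl, on an aromatic carbon ortho to a large group, gives a 31-fold lower number from compound 1 to compound 4 (1.49 log units; beyond the scatter) and so places compound 4 lowest of the four compounds. Within the data shown here, this shows that the group at this one place can move the read-out by a large step, which the earlier compounds could not show, since none of them exchanges one group for another at the same place. Neither iodo nor trifluoromethyl has a hydrogen-bond donor, a hydrogen-bond acceptor or a net charge, so the step arises with these counts unchanged, and nothing at hand accounts for its size.

Going by these compounds, whether the step is particular to trifluoromethyl or would also come with other groups at this aromatic carbon stays open, and a methyl, a methoxy, a chloro or a nitrile group there would test it directly. The compounds shown carry trifluoromethyl at this place only, so its effect at other carbons of the aromatic ring also remains open.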